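Methyl in Place of Methoxy: From Compound 2 to Compound 3

A few compounds are considered here, and "the series" means these few. Any claim that something is new, unique, unknown or untested is made for them only; others in the source may bear on it.

In a functional assay on the whole organism with Mus musculus as the target, at a dose of 50 mg/kg by the oral route (on this read-out higher numbers stand for more inhibition at the one dose given (going by the name of the read-out) and lower numbers for less inhibition), compound 2 `COc1ccccc1/C=C/c1ccccc1OCCCCN(C)C` gives 62.5%, the highest of the two numbers shown, while compound 1 `CN(C)CCCCOc1ccccc1/C=C/c1cccc(Cl)c1` gives 23.9%. Compound 3 `Cc1ccccc1/C=C/c1ccccc1OCCCCN(C)C` differs from compound 2 in that (methyl in place of methoxy on an aromatic carbon). Among the measured compounds shown here, the only measured step, a number 38.6 percentage points higher from compound 1 to compound 2 (beyond the scatter), bears on this change indirectly, since it also altered the group on that ring; it shows the ring substituent can move the read-out well beyond the scatter. Compound 3 is therefore expected to give 45%, from 20% to 70%, with an expected step of a number 17.5 percentage points lower from compound 2 to compound 3 (beyond the scatter).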

Compound 3, a percentage reported as inhibition, in the whole organism at one dose (the size of the read-out at that dose, not a potency): 16.7%
For compound 3 the middle estimate is 28.3 percentage points above the measured one, outside the stated range (below it).
By their numbers in this assay, from the lowest: compounds 3 and 1 (each within the scatter of the next); then compound 2.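

In this assay, the exchange at this place on the aromatic ring, ortho to a large group, is a single change of methoxy to methyl, and it alone gives a number 45.8 percentage points lower from compound 2 to compound 3 (beyond the scatter). The 2-methylphenyl and 3-chlorophenyl groups do not separate, with a number 7.2 percentage points lower from compound 1 to compound 3 (within the scatter), so among these three compounds only the 2-methoxyphenyl group stands apart. Nothing available accounts for this difference. As far as these compounds go, whether an ethoxy or a hydroxy group at this place would hold the number of compound 2 remains open. So does the effect of moving the methoxy group elsewhere on that ring.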